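Chloro to methyl swap and metabolic stability in the series

A few compounds are considered here, and "the series" means these few. Any claim that something is new, unique, unknown or untested is made for them only; others in the source may bear on it.

Compound 1 `CC(=O)Nc1cc(-c2ccc(OC[C@@H](N)CC(C)C)c(C)c2)ccn1`, compound 2 `CC(=O)Nc1cc(-c2ccc(OC[C@@H](N)CC(C)C)c(Cl)c2)ccn1` and compound 3 `Cc1cc(-c2cc(Cl)c(OC[C@@](C)(N)CC(C)C)cn2)ccn1` have been measured in an ADME assay on microsomes from liver (Mus musculus) for metabolic stability, read by LC-MS, using NADPH, with a stated time of 10 min, tested at 0.5 uM; a lower number here means that less of the compound is left, a higher number that more of the compound is left. Compound 2 gives 86%, compound 1 gives 64%, and compound 3 gives 71%. Compound 1 arises from compound 2 by methyl in place of chloro on an aromatic carbon, a change that gave a number 22 percentage points lower from compound 2 to compound 1 (beyond the scatter). Compound 4 `Cc1cc(-c2cc(C)c(OC[C@@](C)(N)CC(C)C)cn2)ccn1`, not yet measured, arises from compound 3 by methyl in place of chloro on an aromatic carbon. The difference between the two cores is not broken down here. The surroundings of the place are not the same: in compound 2 the ring is of carbon only, ortho to a (2-amino-4-methylpentyl)oxy group and meta to a large group, whereas in compound 3 the ring holds 1 nitrogen, ortho to a group of 9 heavy atoms, meta to a 2-methylpyridin-4-yl group and opposite the ring nitrogen, so this is the same kind of change, not the same. The expected step is a number 16 percentage points lower from compound 3 to compound 4 (beyond the scatter), resting on a number 22 percentage points lower from compound 2 to compound 1 (beyond the scatter). The altered surroundings argue for a somewhat smaller step than that earlier one. Compound 4 is therefore estimated at 55% in this assay, most likely between 38% and 72%.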

Compound 4, percent of the compound remaining: 72%
For compound 4 the middle estimate is 17 percentage points below the measured one; the measured number falls inside the stated range.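

In this assay, methyl in place of chloro on the core of compound 3 gives a number 1 percentage points higher from compound 3 to compound 4 (within the scatter) and so does not repeat the loss seen on the other core. The size of this change therefore does not carry from one core to the other in this series, and the two steps differ: the same change on two cores in this assay, a number 22 percentage points lower (beyond the scatter) from compound 2 to compound 1 and a number 1 percentage points higher (within the scatter) from compound 3 to compound 4, 23 percentage points apart, beyond the scatter of two such steps. This rests on one pair per core, and the cores differ in more than one place, so the data do not show which difference between them matters or how the change would behave on a third core.

Open, going by these compounds, is whether fluoro, methoxy or a nitrile at this place would also differ between the two cores. Also open, on these data alone, is whether the ring nitrogen alone would separate the two steps.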